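A few compounds are considered here, and "the series" means these few. Any claim that something is new, unique, unknown or untested is made for them only; others in the source may bear on it.

Measured compounds:
Compound 1 `CCCn1c(=O)[nH]c2nc(-c3ccc(S(=O)(=O)N4CCN(C)CC4)cc3)[nH]c2c1=O` — 334 nM
Compound 2 `CCCn1c(=O)[nH]c2nc(-c3ccc(S(=O)(=O)N4CCN(c5ccccc5)CC4)cc3)[nH]c2c1=O` — 364 nM
Compound 3 `CCCn1c(=O)[nH]c2nc(-c3ccc(S(=O)(=O)N4CCN(c5cccc(Cl)c5)CC4)cc3)[nH]c2c1=O` — > 1000 nM

In an assay on CHO cells for displacement of a labelled ligand from adenosine receptor A1 (Homo sapiens), read by scintillation counting, with a stated time of 90 min, in the presence of a further agent that is not named here (a lower number here means a stronger inhibitor, a higher number a weaker inhibitor), compound 3 gives only a limit, > 1000 nM, not a number. Compound 4 `CCCn1c(=O)[nH]c2nc(-c3ccc(S(=O)(=O)N4CCN(c5ccccc5C)CC4)cc3)[nH]c2c1=O` differs from compound 3 by 2-methylphenyl in place of 3-chlorophenyl on an amine nitrogen in a ring. Among the measured compounds shown here, two measured steps bear on this change. The step of an at least 2.7-fold higher number from compound 2 to compound 3 (0.43 log units; beyond the scatter) shows that adding chloro weakened binding; removing it should recover some of that. The step of a 1.1-fold higher number from compound 1 to compound 2 (0.04 log units; within the scatter) shows that a plain phenyl on the ring nitrogen is tolerated about as well as methyl. For the measured compounds named here, a methyl on the phenyl has no measured precedent here, so the expectation for compound 4 is a modest gain in this assay, toward the level of compound 2, and compound 4 is estimated at 600 nM (range 250 nM to 1500 nM), a step of an at least 1.6-fold lower number from compound 3 to compound 4 (0.22 log units; that floor lies within the scatter).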

Compound 4, inhibition constant: 419 nM
Estimate against measurement, compound 4: 1.4-fold (0.16 log units) above; low and high end bracket the measured number.
By their numbers in this assay, from the lowest: compounds 1, 2 and 4 (each within the scatter of the next). At a limit, above all of these: compound 3.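

In this assay compound 3 gives only a limit (> 1000 nM). Swapping its 3-chlorophenyl for 2-methylphenyl restores binding (an at least 2.3-fold lower number from compound 3 to compound 4 (0.37 log units; beyond the scatter)), so a substituent on this phenyl need not cost binding. Adding the methyl to the plain phenyl (a 1.2-fold higher number from compound 2 to compound 4 (0.06 log units; within the scatter)) and replacing the methyl on the ring nitrogen with 2-methylphenyl (a 1.3-fold higher number from compound 1 to compound 4 (0.10 log units; within the scatter)) both stay within the scatter, so this position accepts 2-methylphenyl as well as it accepts phenyl or methyl.

These compounds cannot separate the effect of the chloro from that of where it sits on the phenyl. Comparing 2-chlorophenyl and 3-methylphenyl would address this, and how a benzyl group on the ring nitrogen would fare also stays open.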